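Series notes: hydrogen in place of nitro, compound 3

The source may report more compounds than this note shows. Statements on the series, on what has been measured and on what is new or still open speak of the compounds shown alone.

Measured so far:
- compound 1 `CCCOC(=O)Nc1ccc([Se]C#N)cc1`: 46300 nM
- compound 2 `N#C[Se]c1ccc(NC(=O)OCc2ccc([N+](=O)[O-])cc2)cc1`: 32800 nM

In an ADME assay on BEAS-2B cells (Homo sapiens) for cytotoxicity, read by MTT assay, with a stated time of 72 h (on this read-out lower numbers stand for stronger inhibition of growth and higher numbers for weaker inhibition of growth), compound 1 gives 46300 nM. Compound 2 gives 32800 nM in this assay, the lowest of the two numbers on hand; the gap to compound 1 is within the scatter, so the two compounds cannot be ranked against each other on these numbers.

Compound 3 `N#C[Se]c1ccc(NC(=O)OCc2ccccc2)cc1` is the next compound to be measured in this assay. It differs from compound 2 in one place: hydrogen in place of nitro on an aromatic carbon, in words, hydrogen in place of nitro on an aromatic carbon. Among the compounds with values here, no pair of measured compounds differs in a single place, so there is no measured step to carry over to this change; the two values on hand show only that the series so far sits in a narrow band of this assay.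

For this step the expectation is a change no larger than the scatter, with no preferred direction. The two measured compounds differ from each other in more than one place, and their values nonetheless lie within the scatter of each other; nothing on hand points in either direction for this change. Compound 3 is therefore estimated at 38000 nM, with a range from 15000 nM to 95000 nM. The step from compound 2 that this estimate means is expected to be a 1.2-fold higher number from compound 2 to compound 3 (0.06 log units; within the scatter).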

Compound 3, concentration for total growth inhibition: 34400 nM
Compound 3: middle estimate off by 1.1-fold (0.04 log units), on the high side; low and high end bracket the measured number.
By their numbers in this assay, from the lowest: compounds 2, 3 and 1 (each within the scatter of the next).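

In this assay, the place on an aromatic carbon para to a large group accepts hydrogen in place of nitro with no change that can be read: the step is a 1.0-fold higher number from compound 2 to compound 3 (0.02 log units; within the scatter), and it gives this position its first single-place comparison. The second single-place comparison, phenyl in place of ethyl on a saturated chain carbon bound to an oxygen next to a carbonyl group, is a 1.3-fold lower number from compound 1 to compound 3 (0.13 log units; within the scatter), so neither of these two changes separates its pair of compounds in this read-out. Nothing on hand gives a reason for either result.

On these data alone, the aromatic position has been seen with only nitro and hydrogen, so it remains open whether an amine, a carboxylic acid or a halogen there would give a step beyond the scatter. On the chain side, a longer chain or a ring bearing an amine could still show whether that part of the compounds has any bearing on growth inhibition of these cells.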